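The source may report more compounds than this note shows. Statements on the series, on what has been measured and on what is new or still open speak of the compounds shown alone.

Series notes on an assay on isolated protein for inhibition of protein deacetylase HDAC6 (Homo sapiens), read by fluorescence; a lower number here means a stronger inhibitor, a higher number a weaker inhibitor. Compound 1 `CC(C)Oc1ccc(C(C)(C)O)cc1-c1cn(C)c(=O)c2[nH]c(C(=O)NCc3ccc(C(=O)NO)cc3)cc12` gives 52 nM in this assay. Compound 3 `O=C(CCCCCCC(=O)Nc1cnc(N(c2ccccc2)c2ccccc2)nc1)NO` gives 4.4 nM. Compound 2 `Cn1cc(-c2ccccc2Oc2ccccc2)c2cc(C(=O)NCCCCC(=O)Nc3ccccc3N)[nH]c2c1=O` reaches only a limit of this assay, reported as > 500 nM, so for compound 2 there is no number but a limit; it sits at the limit of > 500 nM in this assay, at which 1 of the 3 values shown sits. Compound 4 `Cn1cc(-c2ccccc2Oc2ccccc2)c2cc(C(=O)NCCCCC(=O)NO)[nH]c2c1=O` has not yet been measured.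

The change from compound 2 to compound 4 is hydroxy in place of 2-aminophenyl on an amide-type nitrogen. Within the data shown here, no measured pair differs in exactly this way, so the size of the step can only be judged from what the other compounds show: compound 1 and compound 3 both carry a hydroxycarbamoyl group and both give numbers well inside the range of this assay, while compound 2, with the (2-aminophenyl)carbamoyl group, does not. For compound 4 the expected step is an at least 20-fold lower number from compound 2 to compound 4 (1.30 log units; beyond the scatter), toward stronger inhibition and well beyond the scatter. Compound 4 is estimated at 25 nM, with a range from 5 nM to 120 nM.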

Compound 4, half-maximal inhibitory concentration: 4 nM
Compound 4: middle estimate off by 6.3-fold (0.80 log units), on the high side, outside the stated range (below it).
By their numbers in this assay, from the lowest: compounds 4 and 3 (each within the scatter of the next); then compound 1. At a limit, above all of these: compound 2.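

In this assay, putting hydroxy in place of 2-aminophenyl on the amide-type nitrogen, with the shared core and chain unchanged, gives an at least 120-fold lower number from compound 2 to compound 4 (2.09 log units; beyond the scatter) and so puts this group change on a direct footing. Compound 1 and compound 3 could only hint at this, as each also differs from compound 2 elsewhere, whereas this pair differs in one place. Compound 2 reaches a limit and has no number, so the size of the step is only a lower bound: the limit of > 500 nM in this assay, at which 1 of the 4 values shown sits.

Still open, from the compounds shown here alone, is whether a carboxylic acid in place of the hydroxycarbamoyl group, or a longer chain leading to it, would keep the number of compound 4. Also open is whether a step of this size carries over to the core of compound 1 or compound 3, as the compounds shown hold no such pair.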